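Pyrimidin-5-yl for pyrazin-2-yl on the shared core

The source may report more compounds than this note shows. Statements on the series, on what has been measured and on what is new or still open speak of the compounds shown alone.

Measured in a functional assay (trachea) with Cavia porcellus as the target; a lower number here means a stronger inhibitor, a higher number a weaker inhibitor:
- compound 1 `CCn1nc(-n2cncn2)c2ccccc2c1=O`: 15800 nM
- compound 2 `CCn1nc(-c2cncs2)c2ccccc2c1=O`: 562 nM
- compound 3 `CCn1nc(-c2cnccn2)c2ccccc2c1=O`: 11000 nM

Compound 3 cannot be told apart from compound 1, as a 1.4-fold lower number from compound 1 to compound 3 (0.16 log units; within the scatter) shows. The gap to compound 2 is wide: a 20-fold higher number from compound 2 to compound 3 (1.29 log units; beyond the scatter). Compound 2 is the strongest of the three.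

Next is compound 4 `CCn1nc(-c2cncnc2)c2ccccc2c1=O`, with pyrimidin-5-yl in place of pyrazin-2-yl on an aromatic carbon. Among the compounds with values here, no measured step covers this exchange directly. The three steps at this place on the core are the nearest evidence. Both large ones, a 28-fold lower number from compound 1 to compound 2 (1.45 log units; beyond the scatter) and a 20-fold higher number from compound 2 to compound 3 (1.29 log units; beyond the scatter), involve the 1,3-thiazol-5-yl of compound 2, so they show that the group here can matter a great deal. The exchange in a 1.4-fold lower number from compound 1 to compound 3 (0.16 log units; within the scatter) stays within the scatter. Compound 4 keeps a six-membered aromatic ring with 2 hetero atoms, as compound 3 does, so a large step in this assay is not expected. The data give only a slight lean towards a lower number. The expected change is a 1.6-fold lower number from compound 3 to compound 4 (0.20 log units; within the scatter), which would not stand clear of the scatter. For compound 4 the estimated value is 7000 nM, with an expected range of 1500 nM to 25000 nM.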

Compound 4, half-maximal inhibitory concentration: 9550 nM
The estimate for compound 4 lay 1.4-fold (0.13 log units) below the measured number, within the range that was stated.
By their numbers in this assay, from the lowest: compound 2; then compounds 4, 3 and 1 (each within the scatter of the next).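

In this assay, within the data shown here, rearranging the same atoms from pyrazin-2-yl to pyrimidin-5-yl gives no step that can be resolved (a 1.2-fold lower number from compound 3 to compound 4 (0.06 log units; within the scatter)), so this pair of six-membered aromatic rings with 2 hetero atoms does not separate at this position. The exchange of the 1H-1,2,4-triazol-1-yl for pyrimidin-5-yl is also within the scatter (a 1.7-fold lower number from compound 1 to compound 4 (0.22 log units; within the scatter)), whereas the exchange of 1,3-thiazol-5-yl for pyrimidin-5-yl is large (a 17-fold higher number from compound 2 to compound 4 (1.23 log units; beyond the scatter)), leaving compound 2 as the only one of the four clearly apart from the others. Nothing at hand accounts for the close values of compounds 1, 3 and 4 or for the separate place of compound 2.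

Open, going by these compounds, is whether the low number of compound 2 depends on the sulfur atom of its ring, a question that a thiophen-2-yl or a 1,3-oxazol-5-yl at the same position would help to settle. Also open, on these data alone, is how a pyridin-3-yl, a phenyl or a ring carrying an amine or a carboxylic acid would read here, and whether a longer chain in place of the ethyl group would change the value of the 1,3-thiazol-5-yl compound.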